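Triazole side-chain variation and cytotoxicity on fibroblasts

A few compounds are considered here, and "the series" means these few. Any claim that something is new, unique, unknown or untested is made for them only; others in the source may bear on it.

Measured compounds:
compound 1 `O=C1O[C@H]([C@@H](O)Cn2cc(-c3ccc(Br)cc3)nn2)C(OCc2ccccc2)=C1OCc1ccccc1` gives 5100 nM in an ADME assay on HFF cells (Homo sapiens) for cytotoxicity, read by MTT assay, with a stated time of 72 h; on this read-out lower numbers stand for stronger inhibition and higher numbers for weaker inhibition
compound 2 `O=C1O[C@H]([C@@H](O)Cn2cc(-c3cccc(O)c3)nn2)C(OCc2ccccc2)=C1OCc1ccccc1` gives 39000 nM
compound 3 `O=C1O[C@H]([C@@H](O)Cn2cc(CCCCl)nn2)C(OCc2ccccc2)=C1OCc1ccccc1` gives 27100 nM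

Compound 3 holds the second highest number of the three, close to compound 2 and well separated from compound 1, as the step of a 5.3-fold higher number from compound 1 to compound 3 (0.73 log units; beyond the scatter) shows. The new compound 4 `Cc1ccc(S(=O)(=O)NCc2cn(C[C@H](O)[C@H]3OC(=O)C(OCc4ccccc4)=C3OCc3ccccc3)nn2)cc1` differs from compound 3 by ((4-methylphenyl)sulfonyl)amino in place of 2-chloroethyl on a saturated chain carbon bound to an aromatic carbon. Within the data shown here, no measured step alters this part of the chain: the steps of a 7.6-fold higher number from compound 1 to compound 2 (0.88 log units; beyond the scatter) and a 5.3-fold higher number from compound 1 to compound 3 (0.73 log units; beyond the scatter) concern the aryl group on the triazole, and a 1.4-fold lower number from compound 2 to compound 3 (0.16 log units; within the scatter) is within the scatter. The change is therefore expected to give no step beyond the scatter, so a 1.1-fold higher number from compound 3 to compound 4 (0.04 log units; within the scatter) is the estimate. Compound 4 is expected at 30000 nM, within 10000 nM to 90000 nM.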

Compound 4, half-maximal inhibitory concentration: 50 nM
Beside the measured number, compound 4's estimate is 600-fold (2.78 log units) above it; measured number outside the range, below it.
By their numbers in this assay, from the lowest: compound 4; then compound 1; then compounds 3 and 2 (each within the scatter of the next).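

In this assay, among these compounds, ((4-methylphenyl)sulfonyl)amino in place of 2-chloroethyl gives a 540-fold lower number from compound 3 to compound 4 (2.73 log units; beyond the scatter) and shows that this saturated chain carbon bound to an aromatic carbon can carry a far larger change than the earlier steps revealed. The steps of a 780-fold lower number from compound 2 to compound 4 (2.89 log units; beyond the scatter) and a 100-fold lower number from compound 1 to compound 4 (2.01 log units; beyond the scatter) leave compound 4 lowest of the four, beyond the scatter of each. Nothing at hand accounts for the size of this change.

As far as these compounds go, whether the sulfonyl, the amino hydrogen or the 4-methylphenyl ring carries the step remains open. So does the outcome with a plain amine or a carboxamide here.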